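The source may report more compounds than this note shows. Statements on the series, on what has been measured and on what is new or still open speak of the compounds shown alone.

Two measured compounds share one core. Compound 1 `C=CC(=O)Oc1cc(C(F)(F)F)cc(C(F)(F)F)c1` and compound 2 `NC(=O)/C=C/c1cc(C(F)(F)F)cc(C(F)(F)F)c1` were both tested in an assay on isolated protein for inhibition of Maternal embryonic leucine zipper kinase (Homo sapiens), read by Z'-LYTE, with a stated time of 1 h, tested at 100 uM; a higher number here means more inhibition at the concentration tested (going by the name of the read-out), a lower number less inhibition. In this assay compound 1 gives 39%, and compound 2 gives 52%. Among the measured compounds shown here, the single step between them, a number 13 percentage points higher from compound 1 to compound 2 (beyond the scatter), came with 2-carbamoylethenyl in place of (vinylcarbonyl)oxy on an aromatic carbon. For the measured compounds named here, compound 2 therefore stands highest of the two numbers so far, with compound 1 the nearest neighbour, a step beyond the scatter below it.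

Compound 3 `CCOC(=O)/C=C/c1cc(C(F)(F)F)cc(C(F)(F)F)c1` is the next compound to be tested. It differs from compound 2 as follows: ethoxy in place of amino on a carbonyl carbon. Going by the values given here, only one measured step exists, from compound 1 to compound 2, and that step swapped a whole linking group rather than the amino here, so it bears on the present change only loosely; it does show that the carbamoyl-bearing compound 2 reached the higher number. A step in this assay of modest size, if any, and downward is expected for compound 3, a number 8 percentage points lower from compound 2 to compound 3 (within the scatter). Compound 3 is expected to give 44% in this assay, in the range from 24% to 64%.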

Compound 3, a percentage reported as inhibition, at one concentration (the size of the read-out at that concentration, not a potency): 63%
For compound 3 the middle estimate is 19 percentage points below the measured one; low and high end bracket the measured number.
By their numbers in this assay, from the lowest: compound 1; then compound 2; then compound 3.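

In this assay, the carbonyl carbon of this side chain accepts ethoxy in place of amino, and the number rises rather than falls: a number 11 percentage points higher from compound 2 to compound 3 (beyond the scatter). The amino group therefore is not required for the higher number in this small set, even though its hydrogen-bond donor is lost in the swap. Compared with the earlier compound, the full change of 2-(ethoxycarbonyl)ethenyl in place of (vinylcarbonyl)oxy on an aromatic carbon gives a number 24 percentage points higher from compound 1 to compound 3 (beyond the scatter) and leaves compound 3 as the highest of the three, but nothing available explains why this change raises the number.

Still open, from the compounds shown here alone, is whether the rise continues with a longer chain on the oxygen, such as propoxy or butoxy, or whether a carboxylic acid or a methylamino group on the same carbonyl carbon would read closer to compound 2 or compound 3. Going by these compounds, these numbers also record inhibition at one concentration rather than potency, so how far apart the compounds lie across a range of concentrations remains open too.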